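The source may hold more compounds than are shown below. What is called first, only, known or untested is meant among the compounds shown, and "the series" means these compounds.

Compounds with values in hand:

compound 1 `CCc1ncn2c(O)nncc12` — in a functional assay for inhibition, with Homo sapiens as the target (on this read-out lower numbers stand for stronger inhibition and higher numbers for weaker inhibition), compound 1 gives > 48000 nM, a limit of the assay.
compound 2 `COCc1ncc2cnnc(S)n12` — in this assay compound 2 gives > 48000 nM, a limit of the assay.
compound 3 `Cc1ncc2cnnc(S)n12` — in this assay compound 3 gives > 48000 nM, a limit of the assay.

Within the data shown here, every value so far is a limit rather than a number, and compound 3 stands at that limit together with the other two. Among the measured compounds shown here, the one step between neighbours that differ in a single place, a step that the two limits leave unreadable from compound 2 to compound 3, cannot be read in size, since both ends of it are limits; the reason is the limit of > 48000 nM in this assay, at which 3 of the 3 values shown sit.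

Compound 4 `CCCc1ncc2cnnc(S)n12` has not been measured in this assay. It differs from compound 3 by ethyl in place of hydrogen on a saturated chain carbon bound to an aromatic carbon. For the measured compounds named here, no measured step bears on this change: the only step, from compound 2 to compound 3, is unreadable, and the same holds for every pair among compounds 1, 2 and 3. Nothing in the numbers shown points to a change beyond the scatter, in either direction.

The expectation for compound 4 is therefore that it stays where compound 3 stands, with an estimated step that the limit leaves unreadable from compound 3 to compound 4 in this assay. Compound 4 is estimated at 60000 nM in this assay, within 20000 nM to 200000 nM, most likely reported again as a limit.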

Compound 4, half-maximal inhibitory concentration: > 48000 nM
Compound 4: a limit, no number (the forecaster's own chance of this, stated with the estimate: 85%); the middle value lies beyond the limit too.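

In this assay compound 4 gives > 48000 nM, a limit of the assay. The steps from compound 2 and compound 3 to compound 4 cannot be read in size: the limit of > 48000 nM in this assay, at which 4 of the 4 values shown sit.

The compounds shown leave open which change to the shared core, if any, would give a readable number in this assay, and how methoxy, hydrogen and ethyl on the saturated chain carbon compare.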